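This account rests on a few compounds, and the source may have more. Where it says the series, first, only, none or still open, it means among the compounds named here.

Working notes on the series.

Compound 1 `Cc1cc(=O)oc2cc(OCC(O)CN3CCC(C(N)=O)CC3)ccc12` carries no benzyl group on the shared core. In an ADME assay on A549 cells (Homo sapiens) for cytotoxicity, read by CellTiter-Glo (on this read-out lower numbers stand for higher toxicity in this test and higher numbers for lower toxicity in this test), compound 1 gives only a limit, > 100000 nM. For the measured compounds named here, compound 2 `Cc1c(Cc2ccc(Cl)cc2)c(=O)oc2cc(OCC(O)CN3CCC(C(N)=O)CC3)ccc12` adds a 4-chlorobenzyl and in this assay compound 2 gives 40000 nM, the only real number in the set so far. Compound 3 `Cc1cc(F)ccc1Cc1c(C)c2ccc(OCC(O)CN3CCC(C(N)=O)CC3)cc2oc1=O` carries the 4-fluoro-2-methylbenzyl instead. In this assay compound 3 again returns only a limit, > 100000 nM. The two readable steps are an at least 2.5-fold lower number from compound 1 to compound 2 (0.39 log units; beyond the scatter) and an at least 2.5-fold higher number from compound 2 to compound 3 (0.39 log units; beyond the scatter), both pointing the same way: the 4-chlorobenzyl is the one variant that registers as a number, and two of the three values sit at the limit of > 100000 nM in this assay, at which 2 of the 3 values shown sit.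

Compound 4 `Cc1noc(C)c1-c1ccc(Cc2c(C)c3ccc(OCC(O)CN4CCC(C(N)=O)CC4)cc3oc2=O)cc1` is next. Relative to compound 2 the change is 3,5-dimethyl-1,2-oxazol-4-yl in place of chloro on an aromatic carbon. The steps measured so far show that changing the substitution on the benzyl aryl ring moves the read-out by at least a modest amount toward the limit, so for compound 4 a step of a 2.0-fold higher number from compound 2 to compound 4 (0.30 log units; within the scatter) is expected, toward a higher number, with a fair chance the assay reports only a limit. The estimate for compound 4 is 80000 nM, within 30000 nM to 200000 nM.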

Compound 4, half-maximal cytotoxic concentration: 36900 nM
Estimate against measurement, compound 4: 2.2-fold (0.34 log units) above, and the stated range covers the measured number.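

In this assay, the replacement of chloro by 3,5-dimethyl-1,2-oxazol-4-yl, on an aromatic carbon para to a large group, gives a 1.1-fold lower number from compound 2 to compound 4 (0.04 log units; within the scatter). Compound 2 and compound 4 therefore cannot be told apart, although the entering group brings 7 heavy atoms, one five-membered aromatic ring and 2 hydrogen-bond acceptors in place of a single chlorine atom. A measured number is thus no longer confined to the 4-chlorobenzyl variant, while the other two compounds remain limits: the limit of > 100000 nM in this assay, at which 2 of the 4 values shown sit.

From the compounds shown here alone, it remains open whether an amine or a carboxylic acid on this aromatic carbon would also leave the read-out unchanged. One pair also cannot show how far this carbon tolerates change in general.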